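This account rests on a few compounds, and the source may have more. Where it says the series, first, only, none or still open, it means among the compounds named here.

Working notes on the series.

Among the compounds with values here, compound 2 `Cc1ccc(CSc2cc(Cl)c(C)cc2S(=O)(=O)/N=C(\N)n2nccc2-c2ccccc2)cc1` stands at the higher of the two numbers measured so far in an ADME assay on HaCaT cells (Homo sapiens) for cytotoxicity, read by MTT assay, with a stated time of 72 h (a higher number here means a weaker inhibitor, a lower number a stronger inhibitor), where compound 2 gives 20000 nM. Its nearest neighbour is compound 1 `Cc1cc(S(=O)(=O)/N=C(\N)n2nccc2-c2ccccc2)c(SCc2cccc(C(F)(F)F)c2)cc1Cl`, which in this assay gives 18000 nM. Within the data shown here, the only measured step, a 1.1-fold higher number from compound 1 to compound 2 (0.05 log units; within the scatter), lies within the scatter, so the two compounds cannot be ordered.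

Compound 3 `Cc1cc(S(=O)(=O)/N=C(\N)n2nccc2-c2ccccc2)c(SCc2ccc(Cl)cc2)cc1Cl` differs from compound 2 by chloro in place of methyl on an aromatic carbon. Among the measured compounds shown here, the one step that bears on this change is a 1.1-fold higher number from compound 1 to compound 2 (0.05 log units; within the scatter), which swapped the whole aromatic substituent on the benzyl sulfide arm without moving the number beyond the scatter. The change from compound 2 to compound 3 touches the same arm at a single aromatic carbon, so no step beyond the scatter is expected, and the estimated step is no change at the digits printed from compound 2 to compound 3 (within the scatter), in no firm direction. Compound 3 is therefore expected to give about 20000 nM in this assay, with a range from 10000 nM to 40000 nM.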

Compound 3, half-maximal inhibitory concentration: 12000 nM
The estimate for compound 3 lay 1.7-fold (0.22 log units) above the measured number, and the stated range covers the measured number.
By their numbers in this assay, from the lowest: compounds 3, 1 and 2 (each within the scatter of the next).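

In this assay, chloro in place of methyl on an aromatic carbon para to a large group gives a 1.7-fold lower number from compound 2 to compound 3 (0.22 log units; within the scatter), so this position now has two groups on record, and the step stays within the scatter. Setting the 4-chlorophenyl arm against the 3-(trifluoromethyl)phenyl arm gives a 1.5-fold lower number from compound 1 to compound 3 (0.18 log units; within the scatter), also within the scatter, so the three arms on the saturated chain carbon bound to the sulfur read alike and compound 1, compound 2 and compound 3 cannot be ordered. No supporting evidence bearing on these numbers is at hand.

On these data alone, all three compounds carry a substituted phenyl on this arm, so it remains open whether the number stays within the scatter with an amine or a carboxylic acid in place of chloro, or with a longer chain in place of the saturated chain carbon bound to the sulfur. As far as these compounds go, it also remains open whether any change to the shared core, away from this arm, gives a step beyond the scatter in this assay.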